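The source may report more compounds than this note shows. Statements on the series, on what has been measured and on what is new or still open speak of the compounds shown alone.

Compound 2 `O=C(NO)c1ccc(/C=C/c2ccnc(-c3ccccc3O)c2)cc1` and compound 1 `O=C(NO)c1ccc(/C=C/c2ccnc(-c3cc(F)ccc3O)c2)cc1` share one core and differ only by fluoro in place of hydrogen on an aromatic carbon. In a functional assay on HCT-116 cells (Homo sapiens) for antiproliferative activity, read by CellTiter-Glo, with a stated time of 72 h (on this read-out lower numbers stand for stronger inhibition and higher numbers for weaker inhibition), compound 2 gives 1450 nM, while compound 1 gives 2040 nM, a step of a 1.4-fold higher number from compound 2 to compound 1 (0.15 log units; within the scatter). Compound 3 `Cc1ccc(-c2cncc(/C=C/c3ccc(C(=O)NO)cc3)c2)cc1` is built on another core; the difference between the two cores is not broken down here. In this assay compound 3 reaches only a limit, > 10000 nM, the point at which (the limit of > 10000 nM in this assay, at which 1 of the 3 values shown sits). Compound 4 `Cc1ccc(-c2cncc(/C=C/c3ccc(C(=O)NO)cc3)c2)c(F)c1` differs from compound 3 by fluoro in place of hydrogen on an aromatic carbon. This is the same kind of change as from compound 2 to compound 1, though there the fluoro sits meta to a large group and para to a hydroxy group, while here it sits ortho to a large group and meta to a methyl group. The expected step is a step that the limit leaves unreadable from compound 3 to compound 4, kept small because the earlier step of a 1.4-fold higher number from compound 2 to compound 1 (0.15 log units; within the scatter) stayed within the scatter. Compound 4 is therefore estimated at 15000 nM, within 5000 nM to 50000 nM, most likely reported again only as a limit.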

Compound 4, half-maximal inhibitory concentration: 2990 nM
Estimate against measurement, compound 4: 5.0-fold (0.70 log units) above, outside the stated range (below it).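

In this assay, fluoro in place of hydrogen gives an at least 3.3-fold lower number from compound 3 to compound 4 (0.52 log units; beyond the scatter), and the same change does not give a matching step on the two cores: the same change on two cores in this assay, a 1.4-fold higher number (0.15 log units; within the scatter) from compound 2 to compound 1 and an at least 3.3-fold lower number (0.52 log units; beyond the scatter) from compound 3 to compound 4, at least 4.7-fold (0.67 log units) apart, beyond the scatter of two such steps. Compound 3 has only a limit, > 10000 nM. This does not show whether the core itself or the place of the fluoro, here ortho to a large group and meta to a methyl group, accounts for the gap, and two pairs cannot set a rule for the series.

Left open is whether a chloro or a methoxy group in the same place would give a similar step. Also open, going by these compounds, is how fluoro would act at this same place on the core of compound 2.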